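A few compounds are considered here, and "the series" means these few. Any claim that something is new, unique, unknown or untested is made for them only; others in the source may bear on it.

Measured in an ADME assay on HCT-116 cells (Homo sapiens) for cytotoxicity, read by CellTiter-Glo, with a stated time of 72 h; a higher number here means a weaker inhibitor, a lower number a stronger inhibitor:
- Compound 1 `CC1CCN(C2CCN(S(=O)(=O)c3cccc(C(F)(F)F)c3)CC2)CC1`: > 5000 nM (a limit)
- Compound 2 `CC1CCN(C2CCN(S(=O)(=O)c3cccc(N)c3)CC2)CC1`: > 5000 nM (a limit)
- Compound 3 `Cc1cccc(S(=O)(=O)N2CCC(N3CCC(C)CC3)CC2)c1`: > 5000 nM (a limit)

Compound 3 stands at > 5000 nM, and this is a limit of the assay, not a number. It shares that position with the other measured compounds, as shown by the limit of > 5000 nM in this assay, at which 3 of the 3 values shown sit.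

Compound 4 `CC1CCN(C2CCN(S(=O)(=O)c3cccc(-c4ccc5ccccc5c4)c3)CC2)CC1` carries naphthalen-2-yl in place of methyl on an aromatic carbon, meta to a large group: naphthalen-2-yl in place of methyl on an aromatic carbon.

Three measured steps change the group at this position: a step that the two limits leave unreadable from compound 1 to compound 2, a step that the two limits leave unreadable from compound 1 to compound 3 and a step that the two limits leave unreadable from compound 2 to compound 3. None of them gives a size or a direction to carry over. The entering group is also much larger than methyl, amino or trifluoromethyl, so these steps say little about so big a change.

The expectation therefore rests on compound 3, whose limit is > 5000 nM: compound 4 is expected to stay near it, with room left for a stronger result in this assay. The estimated change is a number no higher from compound 3 to compound 4 (the limit leaves the size open). For compound 4 the estimate is 5000 nM, with an expected range from 1500 nM to 10000 nM.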

Compound 4, half-maximal inhibitory concentration: > 5000 nM
Compound 4 ended at the assay's limit; the forecaster's own chance of this, stated with the estimate: 65%; the middle value lies on the limit itself.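

No step from compound 1, compound 2 or compound 3 to compound 4 can be read, because all four compounds stand at a limit of the assay rather than at a number: the limit of > 5000 nM in this assay, at which 4 of the 4 values shown sit.

The compounds shown leave open how strong each one really is in this assay, and whether any group at this aromatic carbon, naphthalen-2-yl included, changes the result at all.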